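Trifluoromethyl in place of methyl: an open question

A few compounds are considered here, and "the series" means these few. Any claim that something is new, unique, unknown or untested is made for them only; others in the source may bear on it.

compound 1 `Cc1ccc(S(=O)(=O)NC(=N)N2CCN(c3cc4c(cc3F)c(=O)c(C(=O)O)cn4C3CC3)CC2)cc1`: 32 nM
compound 2 `CCn1cc(C(=O)O)c(=O)c2cc(F)c(N3CCN(C(=N)NS(=O)(=O)c4ccccc4)CC3)cc21`: 32 nM

In a functional assay on HeLa cells (Homo sapiens) for antiproliferative activity, read by MTT assay, with a stated time of 72 h (a higher number here means a weaker inhibitor, a lower number a stronger inhibitor), compound 1 gives 32 nM, and it stands level with compound 2 at 32 nM. Compound 3 `N=C(NS(=O)(=O)c1ccc(C(F)(F)F)cc1)N1CCN(c2cc3c(cc2F)c(=O)c(C(=O)O)cn3C2CC2)CC1`, which has not yet been measured, carries trifluoromethyl in place of methyl on an aromatic carbon, para to a large group, and otherwise keeps the structure of compound 1: trifluoromethyl in place of methyl on an aromatic carbon. Going by the values given here, no measured pair shows what this exchange does, so the data offer no direction for it. The expectation rests on compound 1 at 32 nM and on the modest size of the change. In this assay the estimated outcome is a 1.1-fold lower number from compound 1 to compound 3 (0.03 log units; within the scatter), which is expected to stay within the scatter. The expected value for compound 3 is 30 nM, with an estimated range of 10 nM to 90 nM.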

Compound 3, half-maximal inhibitory concentration: 32 nM
Compound 3: middle estimate off by 1.1-fold (0.03 log units), on the low side, within the range that was stated.
By their numbers in this assay, from the lowest: compounds 1, 2 and 3 (each within the scatter of the next).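

In this assay, going by these compounds alone, trifluoromethyl in place of methyl on an aromatic carbon, para to a large group, gives no change at the digits printed from compound 1 to compound 3 (within the scatter), and this is the first measured pair for the exchange. At this position, then, a group of 4 heavy atoms stands where a group of 1 heavy atom stood, and the reading stays within the scatter of the 4-methylphenyl compound. No measurement is available that bears on the reason for this result.

The compounds shown leave open whether an amine, a methoxy group or a carboxylic acid on the same aromatic carbon would also read level with compound 1. They also leave open whether the exchange from 4-methylphenyl to 4-(trifluoromethyl)phenyl would read the same with a different group elsewhere on the shared core.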